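Chloro to dimethylamino on the core

The source may report more compounds than this note shows. Statements on the series, on what has been measured and on what is new or still open speak of the compounds shown alone.

Measured compounds and values:
- compound 1 `CCCCCCNc1[nH]ccc2ncnc1-2`, in a functional assay on the whole organism (Pleural cavity) with Rattus norvegicus as the target (on this read-out higher numbers stand for an effect only at larger amounts of compound and lower numbers for an effect already at smaller amounts), compound 1 gives > 9 mg/kg, a limit of the assay.
- compound 2 `Clc1[nH]ccc2ncnc1-2`, in this assay compound 2 gives > 9 mg/kg, a limit of the assay.
- compound 3 `OC[C@H]1OC(n2cnc3c(S)nccc32)[C@H](O)[C@@H]1O`, in this assay compound 3 gives 9 mg/kg.

Compound 2 thus stands at the limit, not at a number; the same is true of compound 1, as stated by the limit of > 9 mg/kg in this assay, at which 2 of the 3 values shown sit. Going by the values given here, only compound 3 returns a measured value, and no pair of measured compounds differs in a single place, so no measured step is available to scale from.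

The unmeasured compound 4 `CN(C)c1[nH]ccc2ncnc1-2` is reached from compound 2 by the change (dimethylamino in place of chloro on an aromatic carbon). Compound 1 already carries an amino substituent on the core and sits at the limit, which gives no sign that an amine at this site brings the compound into the measurable range. No shift beyond the scatter is expected; in this assay the step that the limit leaves unreadable from compound 2 to compound 4 is the estimate here, with compound 4 most likely again reported only as a limit.

For compound 4 the expected value in this assay is 12 mg/kg, in the range 5 mg/kg to 30 mg/kg.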

Compound 4, dose for half-maximal effect: 9 mg/kg
For compound 4 the middle estimate is 1.3-fold (0.12 log units) above the measured one, and the stated range covers the measured number.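

In this assay, the change on the aromatic carbon next to the ring nitrogen gives a number no higher from compound 2 to compound 4 (the limit leaves the size open), the first sign that a substituent at this place can bring the shared core to a measured number. Compound 1, which carries a longer amino chain on the same carbon, gives > 9 mg/kg, a limit of the assay, so an amino substituent at this place does not by itself yield a measured number. The size of the gain from dimethylamino in place of chloro stays unreadable because compound 2 sits at a limit, not at a number: the limit of > 9 mg/kg in this assay, at which 2 of the 4 values shown sit.

Open, as far as these compounds go, is whether the measured number is particular to dimethylamino or also holds for a methylamino group, a cyclic amine such as morpholine, or a methoxy group on the same carbon. Also open, from the compounds shown here alone, is how a sugar, as carried by compound 3, would act on the core of compound 4, since those two compounds differ in more than one place and give no single-change comparison.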